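The source may report more compounds than this note shows. Statements on the series, on what has been measured and on what is new or still open speak of the compounds shown alone.

Compound 1 `Cc1ccc(-n2cc(COc3cccc4cnc(Nc5cccc(Cl)c5)nc34)nn2)c([N+](=O)[O-])c1`: > 25000 nM
Compound 2 `COc1ccccc1-n1cc(COc2cccc3cnc(Nc4cccc(Cl)c4)nc23)nn1`: > 25000 nM
Compound 3 `Clc1cccc(Nc2ncc3cccc(OCc4cn(Cc5c(Cl)cccc5Cl)nn4)c3n2)c1`: 24000 nM

These values come from a functional assay on HCT-116 cells (Homo sapiens) for cytotoxicity, read by cell counting, with a stated time of 48 h; a higher number here means a weaker inhibitor, a lower number a stronger inhibitor. Compound 2 stands at the limit of > 25000 nM in this assay, at which 2 of the 3 values shown sit. Its value is a limit of the assay and not a number. Compound 1 gives > 25000 nM, which is also a limit. Only compound 3 has a true number, 24000 nM.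

Compound 4 `Clc1cccc(Nc2ncc3cccc(OCc4cn(-c5cc(Cl)cc(Cl)c5)nn4)c3n2)c1` has not yet been measured. It carries 3,5-dichlorophenyl in place of 2-methoxyphenyl on an aromatic nitrogen.

Three measured steps change the group on that same nitrogen. Among the compounds with values here, the first is a step that the two limits leave unreadable from compound 1 to compound 2. The others are an at least 1.0-fold lower number from compound 1 to compound 3 (0.01 log units; that floor lies within the scatter) and an at least 1.0-fold lower number from compound 2 to compound 3 (0.01 log units; that floor lies within the scatter). None of them shows a change beyond the scatter, so no clear shift is expected in this assay, in either direction. The expected change is a number no higher from compound 2 to compound 4 (the limit leaves the size open).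

Compound 4 is estimated at 25000 nM, with an expected range of 11000 nM to 55000 nM.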

Compound 4, half-maximal inhibitory concentration: 8000 nM
Compound 4: middle estimate off by 3.1-fold (0.49 log units), on the high side; measured number below the stated range.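

In this assay, within the data shown here, the group on this aromatic nitrogen can shift the number beyond the scatter, which the earlier compounds did not show: 3,5-dichlorophenyl gives an at least 3.1-fold lower number from compound 2 to compound 4 (0.49 log units; beyond the scatter) and an at least 3.1-fold lower number from compound 1 to compound 4 (0.49 log units; beyond the scatter). Compound 1 and compound 2 each stand at a limit of the assay and not at a number, so these two steps give only a floor: the limit of > 25000 nM in this assay, at which 2 of the 4 values shown sit. The comparison between two true numbers also shows a change, a 3.0-fold lower number from compound 3 to compound 4 (0.48 log units; beyond the scatter), even though 2,6-dichlorobenzyl and 3,5-dichlorophenyl both carry chlorine.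

The compounds shown leave open whether the change depends on the chlorines, on their placement, or on the ring sitting directly on the nitrogen. From the compounds shown here alone, it also remains open how a plain phenyl, a 3,5-dimethylphenyl or a chain ending in an amine would behave at this position.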